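A few compounds are considered here, and "the series" means these few. Any claim that something is new, unique, unknown or untested is made for them only; others in the source may bear on it.

Compound 1 `CCCCCCCCCCCCCCCCCCNC(=O)[C@@H]1CSC(c2cccc(O)c2)N1` gives 4000 nM in a functional assay on TSU-Pr1 cells (Homo sapiens) for antiproliferative activity, read by sulforhodamine B assay; on this read-out higher numbers stand for weaker inhibition and lower numbers for stronger inhibition.
Compound 2 `CCCCCCCCCCCCCCCCCCNC(=O)[C@@H]1CSC(c2ccc(OC)cc2)N1` gives 19600 nM in this assay.
Compound 3 `CCCCCCCCCCCCCCCCCCNC(=O)[C@@H]1CSC(c2ccc(OCC)cc2)N1` gives > 20000 nM in this assay, which is a limit of the assay rather than a number.

All three share one core and differ only in the aromatic group on a saturated ring carbon. Compound 3 stands at the weak end of the numbers shown, since its result is a limit of > 20000 nM in this assay, at which 1 of the 3 values shown sits, and not a measured value. Replacing the group of compound 1 gave a 4.9-fold higher number from compound 1 to compound 2 (0.69 log units; beyond the scatter) and an at least 5.0-fold higher number from compound 1 to compound 3 (0.69 log units; beyond the scatter), while lengthening the chain on the oxygen gave an at least 1.0-fold higher number from compound 2 to compound 3 (0.00 log units; that floor lies within the scatter). Compound 4 `CCCCCCCCCCCCCCCCCCNC(=O)[C@@H]1CSC(c2c(OC)cc(OC)cc2OC)N1` is not yet measured; it carries 2,4,6-trimethoxyphenyl in place of 4-ethoxyphenyl on a saturated ring carbon. The measured steps suggest that groups of this type on this carbon sit in the weak region, so no step beyond the scatter is expected, and the result may again be a limit. Compound 4 is therefore expected at about 22000 nM, within 8000 nM to 60000 nM. The expected step is a step that the limit leaves unreadable from compound 3 to compound 4.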

Compound 4, half-maximal inhibitory concentration: 6100 nM
Compound 4: the middle estimate sits 3.6-fold (0.56 log units) above what was measured; the whole stated range lies above it.
By their numbers in this assay, from the lowest: compounds 1 and 4 (each within the scatter of the next); then compound 2. At a limit, above all of these: compound 3.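

Before compound 4, the only result clearly stronger than the others came from the 3-hydroxyphenyl of compound 1, but this change shows that a hydroxyl group is not required at this position. The 2,4,6-trimethoxyphenyl group has no hydrogen-bond donor, yet in this assay it gives a 3.2-fold lower number from compound 2 to compound 4 (0.51 log units; beyond the scatter), an at least 3.2-fold lower number from compound 3 to compound 4 (0.51 log units; beyond the scatter) and a 1.5-fold higher number from compound 1 to compound 4 (0.18 log units; within the scatter), so more methoxy groups on the aromatic ring do not simply go with weaker inhibition here. Compound 3 gives a limit, not a number, so its step to compound 4 is only a floor: the limit of > 20000 nM in this assay, at which 1 of the 4 values shown sits.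

With a single trimethoxyphenyl group among the compounds shown, the effect of the number of methoxy groups cannot be separated from the effect of where they sit. From the compounds shown here alone, how an amine or a carboxylic acid on this aromatic ring would read in this assay also remains open.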